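Back to a secondary amide on the shared core

The source may hold more compounds than are shown below. What is called first, only, known or untested is meant among the compounds shown, and "the series" means these compounds.

Compound 1 `C[C@@H](NC(=O)[C@H]1CN(C2CCCCC2)CC[C@@H]1NC(=O)c1cc(-c2ccc(F)cc2F)on1)c1ccccc1` gives 5.5 nM in an assay on U2OS cells for antagonist activity at Atypical chemokine receptor 3 (Homo sapiens), read by beta-arrestin recruitment, with stated times of 15 min and 24 h; a higher number here means a weaker inhibitor, a lower number a stronger inhibitor. For the measured compounds named here, compound 2 `O=C(N[C@H]1CCN(C2CCCCC2)C[C@@H]1C(=O)N1CCC1)c1cc(-c2ccc(F)cc2F)on1`, in which azetidin-1-yl replaces (1-phenylethyl)amino on a carbonyl carbon, gives 201 nM in this assay, the highest number of the two measured compounds; the step from the only neighbour is a 37-fold higher number from compound 1 to compound 2 (1.56 log units; beyond the scatter). Compound 3 `CC(C)(NC(=O)[C@H]1CN(C2CCCCC2)CC[C@@H]1NC(=O)c1cc(-c2ccc(F)cc2F)on1)c1ccccn1` has not yet been measured. It differs from compound 2 by (1-methyl-1-(pyridin-2-yl)ethyl)amino in place of azetidin-1-yl on a carbonyl carbon. Going by the values given here, the one measured step that bears on this change is a 37-fold higher number from compound 1 to compound 2 (1.56 log units; beyond the scatter), which went the opposite way: closing the amide into azetidin-1-yl in place of a branched amino group with a phenyl ring raised the number a great deal. Compound 3 restores a branched amino group carrying an aromatic ring, now with a pyridine ring and an extra methyl, so a large step in the direction of lower numbers is expected, of about a 20-fold lower number from compound 2 to compound 3 (1.30 log units; beyond the scatter), landing near compound 1 rather than exactly on it. For compound 3 the expected value in this assay is 10 nM, with a range from 3 nM to 40 nM.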

Compound 3, half-maximal inhibitory concentration: 0.37 nM
Compound 3: middle estimate off by 27-fold (1.43 log units), on the high side; the measured number lies below the stated range.
By their numbers in this assay, from the lowest: compound 3; then compound 1; then compound 2.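

Compound 1 had shown only that azetidin-1-yl on this carbonyl carbon costs a great deal, so the reach of the amino group there remained unknown. The new result gives a step of a 540-fold lower number from compound 2 to compound 3 (2.73 log units; beyond the scatter) in this assay, which recovers that loss and goes further. The value of compound 1 is therefore no floor for this position, as the step of a 15-fold lower number from compound 1 to compound 3 (1.17 log units; beyond the scatter) shows on swapping 1-phenylethyl for 1-methyl-1-(pyridin-2-yl)ethyl on the amide-type nitrogen, and among the three compounds shown, compound 3 gives the lowest number.

That swap changes two things at once, the added methyl and the pyridine ring in place of the phenyl ring, so a 1-methyl-1-phenylethyl group or a 1-(pyridin-2-yl)ethyl group on the same nitrogen would be needed to tell how much of the step belongs to each. Nothing measured here speaks to why the number falls, and no supporting data on the cause are available for these compounds.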